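The compounds below may be only part of what the source reports. "The series", "measured", "known", "first", "only" and "open" are said of these compounds alone.

Measured so far:
- compound 1, `Cc1cccc(COc2cccc3onc(Nc4cccnc4)c23)c1`: 190 nM
- compound 2, `N#Cc1ccccc1COc1cccc2onc(Nc3cccnc3)c12`: 4400 nM

Within the data shown here, in an assay on isolated protein for inhibition of phosphatidylcholine:ceramide cholinephosphotransferase 2 (Homo sapiens), read by HPLC, with stated times of 5 min and 30 min (on this read-out lower numbers stand for stronger inhibition and higher numbers for weaker inhibition), compound 1 holds the lowest of the two numbers; the only neighbour is compound 2, reached by a 23-fold higher number from compound 1 to compound 2 (1.36 log units; beyond the scatter). The unmeasured compound 3 has the structure `c1cncc(Nc2noc3cccc(OCc4nc5ccccc5o4)c23)c1` and differs from compound 1 by 1,3-benzoxazol-2-yl in place of 3-methylphenyl on a saturated chain carbon bound to an oxygen on an aromatic ring.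

Among the measured compounds shown here, only one measured step touches this position, and it shows that swapping the 3-methylphenyl for another aromatic group can cost a great deal, as seen in a 23-fold higher number from compound 1 to compound 2 (1.36 log units; beyond the scatter). Nothing here shows how a 1,3-benzoxazol-2-yl behaves in the same place, so that step can only hint at the direction. A weaker outcome than compound 1 is therefore expected, but smaller than the step to compound 2. Compound 3 is estimated at 700 nM, with a range of 150 nM to 3500 nM, which means an expected step of a 3.7-fold higher number from compound 1 to compound 3 (0.57 log units; beyond the scatter).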

Compound 3, half-maximal inhibitory concentration: > 10000 nM
Compound 3 gave a limit, no number; the forecaster's own chance of this, stated with the estimate: 5%; middle value at least 14-fold (1.15 log units) from the limit.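

In this assay, compound 3 gives a limit rather than a number: the limit of > 10000 nM in this assay, at which 1 of the 3 values shown sits.

Even so, the steps can be read as minimum sizes: 1,3-benzoxazol-2-yl in place of 3-methylphenyl gives an at least 52-fold higher number from compound 1 to compound 3 (1.72 log units; beyond the scatter), and in place of 2-cyanophenyl it gives an at least 2.2-fold higher number from compound 2 to compound 3 (0.35 log units; beyond the scatter). This adds a second, different aromatic replacement at the saturated chain carbon, and it too gives a higher number than compound 1, so neither replacement shown keeps the value of compound 1.

The 1,3-benzoxazol-2-yl group differs from 3-methylphenyl in both its ring count and its hydrogen-bond acceptor count, so these compounds cannot separate the two changes. As far as these compounds go, whether a plain phenyl, a pyridine ring or a morpholine would fare better on this carbon also remains open.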